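This account rests on a few compounds, and the source may have more. Where it says the series, first, only, none or still open, it means among the compounds named here.

Measured so far:
compound 1 `Nc1ncnc2c1ncn2[C@@H]1O[C@H](CS[C@H]2CN[C@H](C(=O)O)C2)[C@@H](O)[C@H]1O` — > 1000000 nM.
compound 2 `C[S+](C[C@H]1O[C@@H](n2cnc3c(N)ncnc32)[C@H](O)[C@@H]1O)[C@H]1CN[C@H](C(=O)O)C1` — compound 2 gives > 1000000 nM.

For compound 1 the value > 1000000 nM in a functional assay on HL-60 cells (Homo sapiens) (a higher number here means a weaker inhibitor, a lower number a stronger inhibitor), is a limit of the assay and not a number. For compound 2 the value > 1000000 nM in this assay is likewise a limit and not a number. Both values sit at the same point, (the limit of > 1000000 nM in this assay, at which 2 of the 2 values shown sit), so compound 2 cannot be placed above or below compound 1: the two are indistinguishable on what has been measured, and neither shows measurable inhibition in this assay.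

Compound 3 `C[S+](C[C@H]1O[C@@H](n2cnc3c(N)ncnc32)[C@H](O)[C@@H]1O)C1CN[C@H](C(=O)O)C1` has the same atoms and bonds as compound 2; the only difference is the two compounds have the same atoms and bonds; at least one stereo element is drawn with a configuration in one of them and without one in the other: 1 of 7 stereo elements differ; a stereocentre at a saturated ring carbon is drawn R in compound 2 and without a configuration in compound 3. Among the compounds with values here, no step between measured compounds is available to calibrate such a change. Since compound 2 shows no measurable inhibition, the step of a number no higher from compound 2 to compound 3 (the limit leaves the size open) is expected to be none beyond the scatter, and the read-out for compound 3 is expected to come back as a limit again. Compound 3 is expected to give about 1000000 nM, with a range from 300000 nM to 3000000 nM.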

Compound 3, half-maximal inhibitory concentration: > 1000000 nM
Compound 3 ended at the assay's limit; the forecaster's own chance of this, stated with the estimate: 85%; the middle value sits exactly at the limit.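

In this assay compound 3 gives > 1000000 nM, a limit of the assay and not a number. No step can be read between compound 2 and compound 3, since both stand at the same limit: the limit of > 1000000 nM in this assay, at which 3 of the 3 values shown sit. The compounds shown leave open whether the configuration at that saturated ring carbon has any bearing on inhibition, with this as the only difference in the pair: the fact that one of compounds 2 and 3 is drawn with a defined configuration and the other without, at the place where they differ.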